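Ring-nitrogen acyl groups: from compound 3 to compound 4

The compounds below may be only part of what the source reports. "The series", "measured", "known", "first", "only" and "open" are said of these compounds alone.

Measured in a functional assay on U-87MG ATCC cells (Homo sapiens) for antiproliferative activity; a higher number here means a weaker inhibitor, a lower number a stronger inhibitor:
- compound 1 `Cc1c2c(n3c1CCCN(C)[C@@H](C)[C@H](C)Nc1cc-3ccc1C(N)=O)CC(C)(C)CC2=O`: 133 nM
- compound 2 `CC(=O)N1CCCc2c(C)c3c(n2-c2ccc(C(N)=O)c(c2)N[C@@H](C)[C@@H]1C)CC(C)(C)CC3=O`: 29 nM
- compound 3 `Cc1c2c(n3c1CCCN(C(=O)CN)[C@@H](C)[C@H](C)Nc1cc-3ccc1C(N)=O)CC(C)(C)CC2=O`: 481 nM

Compound 3, at 481 nM, has the highest number of the three in this assay. Compound 4 `COCCC(=O)N1CCCc2c(C)c3c(n2-c2ccc(C(N)=O)c(c2)N[C@@H](C)[C@@H]1C)CC(C)(C)CC3=O` replaces its amino with methoxymethyl on a saturated chain carbon bound to a carbonyl carbon: methoxymethyl in place of amino on a saturated chain carbon bound to a carbonyl carbon.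

The closest evidence is a 17-fold higher number from compound 2 to compound 3 (1.22 log units; beyond the scatter), where amino replaces hydrogen at that same place. The other two steps, a 4.6-fold lower number from compound 1 to compound 2 (0.66 log units; beyond the scatter) and a 3.6-fold higher number from compound 1 to compound 3 (0.56 log units; beyond the scatter), show that the two acyl groups fall on opposite sides of the methyl compound. Among the measured compounds shown here, no measured compound carries methoxymethyl, so how much of the large step is reversed remains open. Removing the amino is expected to recover much of it, though not necessarily all, with compound 2 at 29 nM as the reference. The expected change is a move to a lower number, estimated as a 6.9-fold lower number from compound 3 to compound 4 (0.84 log units; beyond the scatter). For compound 4 the estimated value is 70 nM, with an expected range of 25 nM to 200 nM.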

Compound 4, half-maximal inhibitory concentration: 80 nM
Compound 4: middle estimate off by 1.1-fold (0.06 log units), on the low side; the measured number falls inside the stated range.
By their numbers in this assay, from the lowest: compound 2; then compounds 4 and 1 (each within the scatter of the next); then compound 3.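

In this assay, methoxymethyl in place of amino on the saturated chain carbon bound to a carbonyl carbon gives a 6.0-fold lower number from compound 3 to compound 4 (0.78 log units; beyond the scatter), so the loss seen with amino does not carry over in full to every group at this place. Substitution here still has a cost: methoxymethyl in place of hydrogen gives a 2.8-fold higher number from compound 2 to compound 4 (0.44 log units; beyond the scatter), a modest step beside the large 17-fold higher number from compound 2 to compound 3 (1.22 log units; beyond the scatter). Against methyl on the ring amine nitrogen, (2-methoxyethyl)carbonyl gives a 1.7-fold lower number from compound 1 to compound 4 (0.22 log units; within the scatter), which lies within the scatter, so these two groups cannot be told apart in this assay.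

Nothing in the data shown accounts for the difference between amino and methoxymethyl at this place. Still open, from the compounds shown here alone, is how a hydroxyl, a carboxylic acid or a longer ether chain would read at this place.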